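Triazole ester series: furan-3-yl replacing methyl on the core

The source may hold more compounds than are shown below. What is called first, only, known or untested is meant among the compounds shown, and "the series" means these compounds.

Measured compounds:
compound 1 `COC(=O)c1nc(C)n(-c2ccc(Cl)cc2)n1` — 17500 nM
compound 2 `COC(=O)c1nc(C)n(-c2ccc(F)cc2)n1` — 15200 nM

Both compounds were measured in a functional assay on NPC-TW01 cells (Homo sapiens) for inhibition, read by MTT assay, with a stated time of 72 h; a higher number here means a weaker inhibitor of growth, a lower number a stronger inhibitor of growth. Compound 1 gives 17500 nM and compound 2 gives 15200 nM. The single step between them, a 1.2-fold lower number from compound 1 to compound 2 (0.06 log units; within the scatter), is fluoro in place of chloro on an aromatic carbon; it lies within the scatter, so compound 2 cannot be set apart from compound 1 on the numbers shown, and neither can be called the stronger inhibitor.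

Compound 3 `COC(=O)c1nc(-c2ccoc2)n(-c2ccc(F)cc2)n1` differs from compound 2 by furan-3-yl in place of methyl on an aromatic carbon. Among the compounds with values here, no measured step bears on this change: the only step in hand, a 1.2-fold lower number from compound 1 to compound 2 (0.06 log units; within the scatter), concerns the halogen on the other aromatic ring and says nothing about what a furan-3-yl in place of methyl does on the shared core. The expectation therefore rests on compound 2 alone, and the step of a 1.5-fold lower number from compound 2 to compound 3 (0.18 log units; within the scatter) is estimated as none beyond the scatter, with a wide range to reflect the absence of any relevant comparison.

Compound 3 is thus expected to give about 10000 nM in this assay, estimated between 2500 nM and 40000 nM.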

Compound 3, concentration for 50% growth inhibition: 11700 nM
Estimate against measurement, compound 3: 1.2-fold (0.07 log units) below; measured number inside the range.
By their numbers in this assay, from the lowest: compounds 3, 2 and 1 (each within the scatter of the next).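

In this assay, the aromatic carbon between two ring nitrogen atoms takes furan-3-yl in place of methyl, 5 heavy atoms for 1 and one five-membered aromatic ring added, with a step of a 1.3-fold lower number from compound 2 to compound 3 (0.11 log units; within the scatter) that does not set compound 3 apart from compound 2. The earlier pair spoke only to the halogen on the other aromatic ring, whereas this step shows that a considerably larger group, bringing a hydrogen-bond acceptor that methyl lacks, can stand at this place on the shared core without a change beyond the scatter. No supporting measurement bears on this result, so its basis stays unassigned.

Open, from the compounds shown here alone, is whether any group at this position moves the number beyond the scatter, for example phenyl, furan-2-yl or a dimethylamino group, and whether furan-3-yl behaves the same alongside the chloro substituent of compound 1. Also open, going by these compounds, is how much the methoxycarbonyl group contributes, since a carboxylic acid or a primary amide at that place on the core would test it directly.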